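The source may hold more compounds than are shown below. What is called first, only, known or untested is meant among the compounds shown, and "the series" means these compounds.

Compound 1 `Cn1ccc2cc(-c3ccc4oc(N5CCCC5)nc4c3)ccc21` gives 674 nM in an assay on HEK293 cells for inhibition of Fatty-acid amide hydrolase 1 (Homo sapiens), read by fluorescence; on this read-out higher numbers stand for weaker inhibition and lower numbers for stronger inhibition.
Compound 2 `COc1cccc(-c2ccc3oc(N4Cc5ccccc5C4)nc3c2)c1` gives 28 nM in this assay.

Of the compounds shown here, two have been measured so far. Of the two numbers, compound 2 has the lowest, and the nearest, compound 1, stands a long way above it, well beyond the scatter of repeated measurements. Among the measured compounds shown here, these two compounds differ from each other in more than one place, so no single, clean step between them can be read from the data; what they show is only that compound 2 is the stronger inhibitor of the pair.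

The unmeasured compound 3 `COCc1ccc(-c2ccc3oc(N4Cc5ccccc5C4)nc3c2)cc1OC` keeps the whole of compound 2 and alters it at one spot: methoxymethyl in place of hydrogen on an aromatic carbon. The new group sits ortho to a methoxy group and para to a large group. Nothing measured here tells how such an addition shifts the numbers in this assay, so any expectation rests on compound 2 alone. The step of a 1.8-fold higher number from compound 2 to compound 3 (0.25 log units; within the scatter) is expected to be small, within the scatter or only slightly beyond it, with no firm direction. Compound 3 is therefore estimated at 50 nM, in a range from 12 nM to 200 nM.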

Compound 3, half-maximal inhibitory concentration: 13 nM
Estimate against measurement, compound 3: 3.8-fold (0.59 log units) above, and the stated range covers the measured number.
By their numbers in this assay, from the lowest: compound 3; then compound 2; then compound 1.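

Among the compounds shown here, the change from compound 2 to compound 3 is the first step here that can be read at a single place, since compound 1 and compound 2 differ in more than one. In this assay, putting methoxymethyl in place of hydrogen on this aromatic carbon, ortho to a methoxy group and para to a large group, gives a modest improvement (a 2.2-fold lower number from compound 2 to compound 3 (0.33 log units; beyond the scatter)), so this position tolerates a group of this size and inhibition becomes somewhat stronger rather than being lost. No other measurement bears on why the number moves, so the step stands as an observation without an explanation.

This is one group at one position, so it cannot show whether a plain methyl, a hydroxymethyl, a longer ether chain, an aminomethyl group or a carboxylic acid at the same carbon would lower the number further, leave it unchanged or raise it. It also leaves open whether the effect of methoxymethyl depends on the methoxy group already on that ring, which would take a compound carrying methoxymethyl without that methoxy group to settle.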